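From 4-methylphenyl to 4-nitrophenyl: a small step expected

The source may report more compounds than this note shows. Statements on the series, on what has been measured and on what is new or still open speak of the compounds shown alone.

In a functional assay on HCT-116 cells (Homo sapiens) for inhibition, read by MTT assay, with a stated time of 48 h (on this read-out lower numbers stand for stronger inhibition and higher numbers for weaker inhibition), compound 3 `Cc1ccc(/C=C2\SC(=O)N(CC(=O)Nc3c(C)n(C)n(-c4ccccc4)c3=O)C2=O)cc1` gives 47700 nM. Compound 1 `Cc1c(NC(=O)NCCN2C(=O)S/C(=C\c3ccc([N+](=O)[O-])cc3)C2=O)c(=O)n(-c2ccccc2)n1C` gives 44800 nM, which lies within the scatter of compound 3, so the two count as level. Compound 2 `COc1cc(/C=C2\SC(=O)N(CCNC(=O)Nc3c(C)n(C)n(-c4ccccc4)c3=O)C2=O)cc(OC)c1OC` gives 12500 nM, a clearly lower number than either of them.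

Compound 4 `Cc1c(NC(=O)CN2C(=O)S/C(=C\c3ccc([N+](=O)[O-])cc3)C2=O)c(=O)n(-c2ccccc2)n1C` has not yet been measured. It differs from compound 3 in one place: nitro in place of methyl on an aromatic carbon. This is nitro in place of methyl on an aromatic carbon, so 4-methylphenyl becomes 4-nitrophenyl.

Among the compounds with values here, no measured step isolates this exact swap. The closest evidence is a 3.6-fold lower number from compound 1 to compound 2 (0.55 log units; beyond the scatter), where 3,4,5-trimethoxyphenyl takes the place of 4-nitrophenyl. That step is modest, and it involves a different group and a different chain from those in compound 4. The 4-nitrophenyl group of compound 4 also sits on compound 1, which gives 44800 nM, level with compound 3 even though the two differ in more than one place. The change to compound 4 is therefore expected to stay within the scatter, with no firm direction. The estimate is a 1.1-fold lower number from compound 3 to compound 4 (0.03 log units; within the scatter). For compound 4, the expected value in this assay is 45000 nM, with an estimated range from 20000 nM to 100000 nM.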

Compound 4, half-maximal inhibitory concentration: 91300 nM
Beside the measured number, compound 4's estimate is 2.0-fold (0.31 log units) below it; the measured number falls inside the stated range.
By their numbers in this assay, from the lowest: compound 2; then compounds 1, 3 and 4 (each within the scatter of the next, the first and the last beyond it).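

In this assay, with everything else in compound 3 held fixed, putting nitro in place of methyl on an aromatic carbon, para to a large group, gives a 1.9-fold higher number from compound 3 to compound 4 (0.28 log units; within the scatter) and so leaves the two compounds level. Within the data shown here, the earlier compounds could not show this: their only step, a 3.6-fold lower number from compound 1 to compound 2 (0.55 log units; beyond the scatter) in the same assay, exchanged 4-nitrophenyl for 3,4,5-trimethoxyphenyl, whereas this pair compares 4-methylphenyl and 4-nitrophenyl directly. Here, a swap that adds heavy atoms and two hydrogen-bond acceptors produces no shift beyond the scatter, and no measurement of any property is available to bear on this result.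

Among these compounds, two methyl-to-nitro compounds make only one comparison, so what an amine or a carboxylic acid on this same aromatic carbon would do remains open. Also open, from the compounds shown here alone, is whether 3,4,5-trimethoxyphenyl on the chain of compound 4 would bring the number down towards that of compound 2, at 12500 nM in this assay, or whether that group's effect depends on the chain it accompanies.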